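Swapping a Benzylamino Arm for a Phenylpiperidine

This account rests on a few compounds, and the source may have more. Where it says the series, first, only, none or still open, it means among the compounds named here.

For the measured compounds named here, compound 1 `CC(C(=O)NCc1ccc(C(F)(F)F)nc1NCc1ccc(Cl)cc1)c1ccc(NS(C)(=O)=O)c(F)c1` is the only compound of this set with a reported number: in a functional assay on CHO-K1 cells for antagonist activity at transient receptor potential cation channel subfamily V member 1 (Homo sapiens), read by FLIPR (a higher number here means a weaker inhibitor, a lower number a stronger inhibitor), compound 1 gives 414 nM. Compound 2 `C[C@H](C(=O)NCc1ccc(C(F)(F)F)nc1N1CCC[C@H]1C(=O)N(C)C)c1ccc(NS(C)(=O)=O)c(F)c1` is reported in this assay as "not active" (no number reported), and no number was recorded for it. Compound 3 `CC(C(=O)NCc1ccc(C(F)(F)F)nc1N1CCC(c2ccccc2)CC1)c1ccc(NS(C)(=O)=O)c(F)c1` differs from compound 1 by 4-phenylpiperidin-1-yl in place of (4-chlorobenzyl)amino on an aromatic carbon. Going by the values given here, no measured pair shows a comparable change, so the step is expected to be a moderate loss of potency, estimated as a 3.6-fold higher number from compound 1 to compound 3 (0.56 log units; beyond the scatter). Compound 3 is therefore expected to give about 1500 nM in this assay, with a plausible range from 300 nM to 8000 nM.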

Compound 3, half-maximal inhibitory concentration: 25 nM
For compound 3 the middle estimate is 60-fold (1.78 log units) above the measured one; measured number outside the range, below it.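

At this aromatic carbon next to the ring nitrogen, the core holds a much larger arm than the (4-chlorobenzyl)amino of compound 1: 4-phenylpiperidin-1-yl gives a 17-fold lower number from compound 1 to compound 3 (1.22 log units; beyond the scatter) and so a large gain in potency. The amino hydrogen-bond donor of the leaving arm is therefore not required here, since compound 3 has none on its arm. No measurement shown explains this gain.
The two arms differ in several features at once, so the share of the piperidine ring and of the lost chlorine stays unresolved. As far as these compounds go, how a plain piperidin-1-yl or a 4-(4-chlorophenyl)piperidin-1-yl arm would behave remains open.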